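The source may hold more compounds than are shown below. What is called first, only, known or untested is meant among the compounds shown, and "the series" means these compounds.

Measured in a functional assay on HT-1080 cells (Homo sapiens) for cytotoxicity, read by MTT assay, with a stated time of 72 h; a higher number here means a weaker inhibitor, a lower number a stronger inhibitor:
Compound 1 `COc1ccc(/C=C2\CCC/C(=C\c3cccc(OC)c3OC)C2=O)cc1OC`: 6400 nM
Compound 2 `COc1cc(/C=C2\CCC/C(=C\c3cccc(OC)c3OC)C2=O)ccc1O`: 5900 nM
Compound 3 `COc1cccc(/C=C2\CCC/C(=C\c3ccc(OC)c(OC)c3)C2=O)c1`: 4600 nM

Compound 3, at 4600 nM, lies within the scatter of the other two values. Unmeasured compound 4 `COc1ccc(/C=C2\CCC/C(=C\c3ccc(Cl)c(Cl)c3)C2=O)cc1OC` differs from it as follows: 3,4-dichlorophenyl in place of 3-methoxyphenyl on a double-bonded chain carbon bound to a double-bonded ring carbon. Among the compounds with values here, two measured steps bear on this only loosely: a 1.4-fold lower number from compound 1 to compound 3 (0.14 log units; within the scatter), which alters the same aromatic ring, and a 1.1-fold lower number from compound 1 to compound 2 (0.04 log units; within the scatter), which alters the other one. Within the data shown here, both stay within the scatter, and neither introduces chlorine, so the series offers no direct precedent. No change beyond the scatter is therefore expected in this assay, and the expected step is a 1.2-fold lower number from compound 3 to compound 4 (0.06 log units; within the scatter). For compound 4 the estimate is 4000 nM, with an expected range of 1500 nM to 10000 nM.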

Compound 4, half-maximal inhibitory concentration: 3100 nM
Beside the measured number, compound 4's estimate is 1.3-fold (0.11 log units) above it; measured number inside the range.
By their numbers in this assay, from the lowest: compounds 4, 3, 2 and 1 (each within the scatter of the next, the first and the last beyond it).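

In this assay, the swap at this position gives a 1.5-fold lower number from compound 3 to compound 4 (0.17 log units; within the scatter), so replacing the methoxy-bearing ring with a chlorine-bearing one leaves the number within the scatter. Compound 4 is the only compound shown that carries chlorine, and it extends the earlier ring changes to a different kind of substituent without a step beyond the scatter. No available data account for this step.

From the compounds shown here alone, whether an amine or a carboxylic acid on this ring would move the number beyond the scatter remains open. The compounds shown also leave open how a single chlorine would compare with 3,4-dichlorophenyl.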